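Swapping chloro for methyl on a mast cell inhibitor

The source may report more compounds than this note shows. Statements on the series, on what has been measured and on what is new or still open speak of the compounds shown alone.

Within the data shown here, in a functional assay (mast cells) with Rattus norvegicus as the target (on this read-out higher numbers stand for weaker inhibition and lower numbers for stronger inhibition), compound 1 `Oc1nnc(-c2nc3cc(Cl)ccc3o2)o1` gives 350 nM as the lowest of the three numbers so far. Compound 3 `Cc1cccc2oc(-c3nnc(O)o3)nc12` at 1000 nM and compound 2 `Cc1ccc2nc(-c3nnc(O)o3)oc2c1` at 5000 nM both stand higher, beyond the scatter, and each carries a methyl on the shared core. Compound 4 `Cc1ccc2oc(-c3nnc(O)o3)nc2c1` has not yet been measured. It is compound 1 with methyl in place of chloro on an aromatic carbon and nothing else changed. Since both measured methyl compounds sit above compound 1 350 nM on this scale, weaker inhibition beyond the scatter is expected, an estimated 4.3-fold higher number from compound 1 to compound 4 (0.63 log units; beyond the scatter) in this assay for this one swap. For compound 4 the estimated value is 1500 nM with an expected range from 500 nM to 5000 nM around it.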

Compound 4, half-maximal inhibitory concentration: 400 nM
Compound 4: the middle estimate sits 3.8-fold (0.57 log units) above what was measured; measured number below the stated range.
By their numbers in this assay, from the lowest: compounds 1 and 4 (each within the scatter of the next); then compound 3; then compound 2.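

In this assay the swap of chloro for methyl on this aromatic carbon gives a 1.1-fold higher number from compound 1 to compound 4 (0.06 log units; within the scatter), so at this position the two groups cannot be told apart. Compound 2 and compound 3 carry their methyl elsewhere on the shared core, so their higher numbers do not carry over to this position. Nothing measured here explains why the two groups read alike. Still open, on these data alone, is whether an amine, a carboxylic acid or a longer chain on this same carbon would give a similar number.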